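Nitro for chloro on the shared core of compound 2

The source may report more compounds than this note shows. Statements on the series, on what has been measured and on what is new or still open speak of the compounds shown alone.

Measured compounds in a functional assay on DU-145 cells (Homo sapiens) for cytotoxicity, read by MTT assay, with a stated time of 48 h; a lower number here means a stronger inhibitor, a higher number a weaker inhibitor:
compound 1 `CCn1c(/C=C2/C(=O)Nc3ccccc32)nc2ccccc21` — its value in this assay is a limit: > 50000 nM
compound 2 `CCn1c(/C=C2/C(=O)Nc3ccc(Cl)cc32)nc2ccccc21` — its value in this assay is a limit: > 50000 nM

Compound 2 stands at no number in this assay, only at a limit. The step from one measured compound to the other, a step that the two limits leave unreadable from compound 1 to compound 2, cannot be sized, since both values are limits; what the two share is the limit of > 50000 nM in this assay, at which 2 of the 2 values shown sit. Compound 3 `CCn1c(/C=C2/C(=O)Nc3ccc([N+](=O)[O-])cc32)nc2ccccc21` differs from compound 2 in one place: nitro in place of chloro on an aromatic carbon. For the measured compounds named here, this is the only structural change under consideration, and the single measured step bears on it only loosely: it shows that a chloro in place of hydrogen on the same aromatic carbon of the shared core left compound 2 at the limit, without telling how far beneath the limit either compound might lie. Going by the values given here, no measured step shows a gain or loss of more than the scatter. The expectation is therefore that compound 3 also sits at or beyond the limit, with the step from compound 2 estimated as a step that the limit leaves unreadable from compound 2 to compound 3. On that basis compound 3 is estimated at 60000 nM, within the range from 15000 nM to 300000 nM.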

Compound 3, half-maximal inhibitory concentration: > 50000 nM
Compound 3: only a limit was reported (the forecaster's own chance of this, stated with the estimate: 80%); the middle value is on the limit's open side.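

For the compounds shown here, no step among compound 1, compound 2 and compound 3 can be read in this assay, since all three values are limits: the limit of > 50000 nM in this assay, at which 3 of the 3 values shown sit. The compounds shown leave open how far beyond that limit each of them lies, and whether chloro or nitro in place of hydrogen on the shared core changes the read-out at all.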